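This account rests on a few compounds, and the source may have more. Where it says the series, first, only, none or still open, it means among the compounds named here.

Measured so far in a functional assay on MCF7 cells (Homo sapiens) for antiproliferative activity; a lower number here means a stronger inhibitor, a higher number a weaker inhibitor:
- compound 1 `CC(=O)Oc1ccc(C(=O)Nc2cc3ccc(OCC4CCCN(C)C4)c(C)c3oc2=O)cc1CC=C(C)C` gives 1650 nM
- compound 2 `CC(=O)Oc1ccc(C(=O)Nc2cc3ccc(OCC4CCCNC4)c(C)c3oc2=O)cc1CC=C(C)C` gives 820 nM
- compound 3 `CCNCCCOc1ccc2cc(NC(=O)c3ccc(O)c(CC=C(C)C)c3)c(=O)oc2c1C` gives 980 nM

Compound 3 sits among the other two, within the scatter of both, so these values give no order. Compound 4 `CC(C)=CCc1cc(C(=O)Nc2cc3ccc(OCCCN(C(C)C)C(C)C)c(C)c3oc2=O)ccc1O` changes the end of the chain of compound 3 : diisopropylamino in place of ethylamino on a saturated chain carbon, three bonds along the chain from an oxygen on an aromatic ring. Going by the values given here, the only measured step also alters a group on an amine nitrogen, though in a ring: a 2.0-fold lower number from compound 1 to compound 2 (0.30 log units; within the scatter). Among the compounds with values here, that step stays within the scatter, and no measured compound carries diisopropylamino, so the guidance is weak. No change beyond the scatter is expected in this assay. The expected change is a 1.1-fold higher number from compound 3 to compound 4 (0.05 log units; within the scatter). Compound 4 is estimated at 1100 nM, with an expected range of 420 nM to 2900 nM.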

Compound 4, half-maximal inhibitory concentration: 1310 nM
The estimate for compound 4 lay 1.2-fold (0.08 log units) below the measured number; the range from low to high includes it.
By their numbers in this assay, from the lowest: compounds 2, 3, 4 and 1 (each within the scatter of the next).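

In this assay, swapping ethylamino for diisopropylamino at the end of the chain, with 7 heavy atoms instead of 3 and 0 hydrogen-bond donors instead of 1, gives a 1.3-fold higher number from compound 3 to compound 4 (0.13 log units; within the scatter). For this pair, the larger group and the loss of the hydrogen on the nitrogen leave the activity within the usual scatter. Nothing available explains this result. On these data alone, whether this position needs an amine at all stays open, and a carboxylic acid there would address that. As far as these compounds go, the effect of a longer chain also remains open.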